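The compounds below may be only part of what the source reports. "The series", "measured", "known", "first", "only" and "open" are said of these compounds alone.

Compound 1 `Nc1nn(C(=O)Nc2ccc(Cc3ccccc3)cc2)c2ccccc12`, in a functional assay on UACC-257 cells (Homo sapiens) for antiproliferative activity, read by sulforhodamine B assay, with a stated time of 48 h; on this read-out lower numbers stand for higher toxicity in this test and higher numbers for lower toxicity in this test: > 100000 nM, a limit of the assay.
Compound 2 `Nc1nn(C(=O)Nc2ccc(Cc3ccccc3)cc2)c2ccc(Cl)cc12`, in this assay: > 100000 nM, likewise a limit of the assay.

Compound 2 therefore stands at the limit of the assay, the point where both values shown sit (the limit of > 100000 nM in this assay, at which 2 of the 2 values shown sit). Within the data shown here, the one step that joins the two measured compounds, a step that the two limits leave unreadable from compound 1 to compound 2, is unreadable because both of its ends sit at the limit (the limit of > 100000 nM in this assay, at which 2 of the 2 values shown sit); it says nothing about how a change on this aromatic carbon moves the read-out. Compound 3 `Nc1ccc2c(c1)c(N)nn2C(=O)Nc1ccc(Cc2ccccc2)cc1` differs from compound 2 by amino in place of chloro on an aromatic carbon. Among the measured compounds shown here, the only measured step bears on this change in that it also alters the same aromatic carbon of compound 2, but its size is not readable, so no direction and no size of step in this assay can be taken from it, and no step beyond the scatter is expected. For compound 3 the value in this assay is estimated at 150000 nM, within 30000 nM to 1000000 nM, and most likely once more reported only as a limit. The step thereby expected is a step that the limit leaves unreadable from compound 2 to compound 3.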

Compound 3, concentration lethal to 50% of the cells: 60800 nM
The estimate for compound 3 lay 2.5-fold (0.39 log units) above the measured number; measured number inside the range.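

Compound 3 is the first compound shown to give a number rather than a limit in this assay, so this aromatic carbon now offers readable steps, whereas the step that put chloro in place of hydrogen there could not be read. Amino in place of chloro gives an at least 1.6-fold lower number from compound 2 to compound 3 (0.21 log units; that floor lies within the scatter), and amino in place of hydrogen gives an at least 1.6-fold lower number from compound 1 to compound 3 (0.21 log units; that floor lies within the scatter). Both figures are floors and not full sizes, and neither by itself establishes a change beyond the scatter, because each step starts from a compound held at a limit: the limit of > 100000 nM in this assay, at which 2 of the 3 values shown sit.

As far as these compounds go, how far the true steps extend past these floors stays open, so the amino group's full effect on the read-out in this assay cannot yet be sized. Also open, from the compounds shown here alone, is whether a hydroxyl, a methoxy or an acetamide group on this same aromatic carbon would give a number in this assay, or whether an amino group on another carbon of this six-membered ring would do so.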